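Adding a Second Chloro Ortho to the First

A few compounds are considered here, and "the series" means these few. Any claim that something is new, unique, unknown or untested is made for them only; others in the source may bear on it.

Measured compounds:
compound 1 `Cc1cc(C(=O)O)c(C)n1-c1cccc(Cl)c1C#N`: 2000 nM
compound 2 `Cc1cc(C(=O)O)c(C)n1-c1cccc(Cl)c1`: 430 nM

For the measured compounds named here, in an assay on cells for inhibition of Palmitoleoyl-protein carboxylesterase NOTUM variant C330S (Homo sapiens), read by fluorescence, with a stated time of 40 min (a higher number here means a weaker inhibitor, a lower number a stronger inhibitor), compound 2 gives 430 nM, the lowest of the two numbers; its nearest neighbour is compound 1, and the single measured step is a 4.7-fold lower number from compound 1 to compound 2 (0.67 log units; beyond the scatter). Compound 3 `Cc1cc(C(=O)O)c(C)n1-c1cccc(Cl)c1Cl` has not yet been measured. It differs from compound 2 by chloro in place of hydrogen on an aromatic carbon, the new group sitting on an aromatic carbon of a six-membered aromatic ring of carbon only, ortho to a chloro group and ortho to a large group. Going by the values given here, the only step that bears on this change is a 4.7-fold lower number from compound 1 to compound 2 (0.67 log units; beyond the scatter), which concerns a cyano group on the same aromatic carbon; no measured step involves a chloro group there. On that slender basis a weakening of modest size, or none beyond the scatter, is expected in this assay. Compound 3 is therefore estimated at 700 nM, within a range of 200 nM to 2500 nM. This estimate means a step of a 1.6-fold higher number from compound 2 to compound 3 (0.21 log units; within the scatter).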

Compound 3, half-maximal inhibitory concentration: 220 nM
For compound 3 the middle estimate is 3.2-fold (0.50 log units) above the measured one; low and high end bracket the measured number.
By their numbers in this assay, from the lowest: compounds 3 and 2 (each within the scatter of the next); then compound 1.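

In this assay there is a 2.0-fold lower number from compound 2 to compound 3 (0.29 log units; within the scatter), so chloro in place of hydrogen on this aromatic carbon, ortho to a chloro group and ortho to a large group, makes no difference that can be told from the scatter. The same carbon does distinguish between groups: there is a 9.1-fold lower number from compound 1 to compound 3 (0.96 log units; beyond the scatter), so the loss seen with the cyano group does not extend to every group placed there. Nothing given here explains either step.

From the compounds shown here alone, whether a methyl, a methoxy group or an amine on this carbon would match hydrogen and chloro or fall with the cyano group remains open. So does whether the new chloro group would behave the same way without the chloro group already on the ring.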